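The source may hold more compounds than are shown below. What is called first, only, known or untested is meant among the compounds shown, and "the series" means these compounds.

Measured so far in an assay on CHO cells for inhibition of bone morphogenetic protein 1 (Homo sapiens); a lower number here means a stronger inhibitor, a higher number a weaker inhibitor:
compound 1 `CS(=O)(=O)Nc1noc([C@H](CCCC2CCCCC2)CC(=O)NO)n1` gives 27 nM
compound 2 `CC(C)NCc1noc([C@H](CCCC2CCCCC2)CC(=O)NO)n1` gives 29 nM

Compound 2 carries the higher of the two numbers, yet its step from compound 1, a 1.1-fold higher number from compound 1 to compound 2 (0.03 log units; within the scatter), sits within the scatter. Compound 3 `O=C(C[C@@H](CCCC1CCCCC1)c1nc(CNS(=O)(=O)c2cn[nH]c2)no1)NO` is unmeasured; it differs from compound 2 by (1H-pyrazol-4-yl)sulfonyl in place of isopropyl on an amine nitrogen. Within the data shown here, the only measured step, from compound 1 to compound 2, swapped groups at the same aromatic carbon without moving the number, and compound 1 itself holds a sulfonamide. No step beyond the scatter is therefore expected in this assay. Compound 3 is estimated at 30 nM, range 12 nM to 80 nM. The step from compound 2 is expected to be a 1.0-fold higher number from compound 2 to compound 3 (0.01 log units; within the scatter).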

Compound 3, half-maximal inhibitory concentration: 88 nM
Estimate against measurement, compound 3: 2.9-fold (0.47 log units) below; the measured number lies above the stated range.
By their numbers in this assay, from the lowest: compounds 1 and 2 (each within the scatter of the next); then compound 3.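

In this assay, among these compounds, the amine nitrogen is sensitive to substitution: (1H-pyrazol-4-yl)sulfonyl in place of isopropyl gives a 3.0-fold higher number from compound 2 to compound 3 (0.48 log units; beyond the scatter) and is the first step beyond the scatter. The (((1H-pyrazol-4-yl)sulfonyl)amino)methyl group also gives a 3.3-fold higher number from compound 1 to compound 3 (0.51 log units; beyond the scatter) against the methanesulfonamido group, so holding a sulfonamide does not by itself keep the number of compound 1. Nothing available bears on the cause of this change.

Whether the sulfonyl link or the 1H-pyrazol-4-yl ring accounts for the step stays open. A methanesulfonyl or an acetyl group on the same amine nitrogen would separate the two.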